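Branching the Carbamate Chain: From Compound 2 to Compound 4

The source may hold more compounds than are shown below. What is called first, only, known or untested is meant among the compounds shown, and "the series" means these compounds.

Measured compounds in a functional assay on HCT-116 cells (Homo sapiens) for cytotoxicity, read by MTT assay; a lower number here means a stronger inhibitor, a higher number a weaker inhibitor:
Compound 1 `CCOC(=O)Nc1ccc(S(=O)(=O)N2C[C@H](c3ccccc3)NC2=O)cc1C` gives 70 nM.
Compound 2 `CCCCOC(=O)Nc1ccc(S(=O)(=O)N2C[C@H](c3ccccc3)NC2=O)cc1CC` gives 200 nM.
Compound 3 `Cc1cc(S(=O)(=O)N2C(=O)N[C@@H](c3ccccc3)C2C)ccc1NC(=O)c1ccc([N+](=O)[O-])cc1` gives > 10000 nM, which is a limit of this assay and not a number (the limit of > 10000 nM in this assay, at which 1 of the 3 values shown sits).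

Of the two numbers, compound 2 stands highest, and its gap to compound 1 lies beyond the usual scatter. Compound 4 `CCc1cc(S(=O)(=O)N2C[C@H](c3ccccc3)NC2=O)ccc1NC(=O)OCC(C)C` has not yet been measured; it differs from compound 2 by isopropyl in place of propyl on a saturated chain carbon bound to an oxygen next to a carbonyl group, the two having the same atoms joined differently. Nothing among these three compounds shows how such a branching of the chain affects this assay, so the step from compound 2 to compound 4 is expected to be small, no change at the digits printed from compound 2 to compound 4 (within the scatter), none beyond the scatter. Compound 4 is therefore estimated at 200 nM, within 80 nM to 500 nM.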

Compound 4, half-maximal inhibitory concentration: 60 nM
Estimate against measurement, compound 4: 3.3-fold (0.52 log units) above, outside the stated range (below it).
By their numbers in this assay, from the lowest: compounds 4 and 1 (each within the scatter of the next); then compound 2. At a limit, above all of these: compound 3.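

In this assay, the carbamate chain proves sensitive to how its atoms are joined, not only to which atoms it contains: changing butoxycarbonyl to isobutoxycarbonyl gives a 3.3-fold lower number from compound 2 to compound 4 (0.52 log units; beyond the scatter). Among the compounds shown here, the earlier compounds offered no such matched pair, so this is the first direct reading of branching at this place. Nothing measured here explains the step.

As far as these compounds go, whether a longer branched chain, a cyclopropylmethyl group or a terminal amine on the chain would lower the number further remains open. So does whether branching nearer the oxygen would act similarly.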